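The compounds below may be only part of what the source reports. "The series", "measured", "known", "first", "only" and "open" are said of these compounds alone.

Of the compounds shown here, two have been measured so far. Compound 1 `O=C(O)/C=C/C(=O)c1ccc(Br)cc1` carries a bromo group on its core; in a functional assay on K562 cells (Homo sapiens) for inhibition, read by MTT assay, with a stated time of 72 h (on this read-out higher numbers stand for weaker inhibition and lower numbers for stronger inhibition), compound 1 gives 11200 nM. Compound 2 `Cc1ccc(C(=O)/C=C/C(=O)O)c(Cl)c1` is the other measured compound, and in this assay compound 2 gives 14600 nM. Compound 1 stands at the low end of these two numbers, but its gap to compound 2 lies within the scatter of repeated measurements, so no order between them can be claimed. Compound 3 `CCCCc1ccc(C(=O)/C=C/C(=O)O)cc1` has not yet been measured. It differs from compound 1 in one place: butyl in place of bromo on an aromatic carbon, the new group sitting on an aromatic carbon of a six-membered aromatic ring of carbon only, para to a group of 7 heavy atoms. Among the measured compounds shown here, no measured pair shows such a change, so the expectation rests on the two values alone. Since both sit close together, the step from compound 1 to compound 3 in this assay is expected to be small, within the scatter, with perhaps a slight drift toward smaller numbers: a 1.2-fold lower number from compound 1 to compound 3 (0.09 log units; within the scatter). Compound 3 is estimated at 9000 nM in this assay, with a range from 3000 nM to 27000 nM.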

Compound 3, half-maximal inhibitory concentration: 4950 nM
Beside the measured number, compound 3's estimate is 1.8-fold (0.26 log units) above it; low and high end bracket the measured number.
By their numbers in this assay, from the lowest: compound 3; then compounds 1 and 2 (each within the scatter of the next).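

In this assay, butyl in place of bromo on an aromatic carbon, para to a group of 7 heavy atoms, gives a 2.3-fold lower number from compound 1 to compound 3 (0.35 log units; beyond the scatter), a modest step and the first in this set that lies beyond the scatter. This position therefore accepts the butyl chain in place of bromo with no rise in the number, although this rests on a single pair of compounds. Nothing shown here explains why the number falls with this change.

The compounds shown leave open whether a shorter chain such as ethyl or a longer chain such as hexyl on this aromatic carbon would lower the number further or raise it again. They also leave open how an amine or a methoxy group would compare with butyl there, and whether butyl would bring a similar step on the core of compound 2.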